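This account rests on a few compounds, and the source may have more. Where it says the series, first, only, none or still open, it means among the compounds named here.

Compound 3, with structure `O=c1nc(-c2ccccc2)c2cc(-c3cc[nH]n3)ccc2[nH]1`, is one of three compounds that have been tested in an ADME assay on THP-1 cells (Homo sapiens) for cytotoxicity, read by MTT assay, with a stated time of 72 h; a lower number here means that less compound is needed, a higher number that more compound is needed for the effect. In this assay compound 3 gives > 50000 nM, which is a limit of the assay and not a number. Compound 1, with structure `Cc1cncc(-c2ccc3[nH]c(=O)nc(-c4ccccc4)c3c2)c1`, gives > 50000 nM in this assay, again a limit. Compound 2, with structure `O=c1nc(-c2ccccc2)c2cc(-c3cccc(F)c3)ccc2[nH]1`, gives > 50000 nM in this assay, also a limit. Because all three sit at the limit of > 50000 nM in this assay, at which 3 of the 3 values shown sit, the steps between them cannot be sized: from compound 1 to compound 2 there is a step that the two limits leave unreadable from compound 1 to compound 2, from compound 1 to compound 3 there is a step that the two limits leave unreadable from compound 1 to compound 3, and from compound 2 to compound 3 there is a step that the two limits leave unreadable from compound 2 to compound 3.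

Compound 4, with structure `CN1CCN(c2ccc3[nH]c(=O)nc(-c4ccccc4)c3c2)CC1`, has not yet been measured. It differs from compound 3 in one place: 4-methylpiperazin-1-yl in place of 1H-pyrazol-3-yl on an aromatic carbon. The three measured steps, each exchanging the group at this same position, all left the value at the limit, so they give no sign of any direction of change. The expected step that the limit leaves unreadable from compound 3 to compound 4 from compound 3 to compound 4 is therefore none beyond the scatter. Compound 4 is expected to give an estimated 60000 nM in this assay, within a range from 20000 nM to 200000 nM, most likely reported as a limit once more.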

Compound 4, half-maximal effective concentration: > 50000 nM
Compound 4: no number, only a limit; the forecaster's own chance of this, stated with the estimate: 75%; the middle value does not contradict the limit.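

In this assay compound 4 gives > 50000 nM, a limit of the assay and not a number. No step from compound 1, compound 2 or compound 3 to compound 4 can be read, because all four compounds share one limit: the limit of > 50000 nM in this assay, at which 4 of the 4 values shown sit.

The compounds shown leave open at what concentration any of them would reach the half-maximal effect, and whether exchanging the group at this position changes that concentration at all.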